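Extending 2-methylphenyl to 2-ethylphenyl: an expected stability

A few compounds are considered here, and "the series" means these few. Any claim that something is new, unique, unknown or untested is made for them only; others in the source may bear on it.

compound 1 `COc1cccc(-c2nc3c(N4CCN(C)CC4)nc(C)nc3n2C2CCOCC2)c1`: 46%
compound 2 `Cc1nc(N2CCN(C)CC2)c2nc(-c3ccccc3F)n(C3CCOCC3)c2n1`: 21%
compound 3 `Cc1nc(N2CCN(C)CC2)c2nc(-c3ccccc3C)n(C3CCOCC3)c2n1`: 39%

In an ADME assay (liver) for metabolic stability, with Liver microsome (Canis lupus familiaris) as the target, read by LC-MS, using microsomes, with a stated time of 30 min, tested at 4 uM (on this read-out higher numbers stand for a more stable compound and lower numbers for a less stable compound), compound 3 gives 39%. The nearest measured comparison is a number 7 percentage points lower from compound 1 to compound 3 (within the scatter), whereas the other is a number 18 percentage points higher from compound 2 to compound 3 (beyond the scatter). Compound 4 `CCc1ccccc1-c1nc2c(N3CCN(C)CC3)nc(C)nc2n1C1CCOCC1` differs at one place: methyl in place of hydrogen on a saturated chain carbon bound to an aromatic carbon. Going by the values given here, no measured step makes this exact change. The measured swaps replaced a whole group, and the largest was a number 25 percentage points lower from compound 1 to compound 2 (beyond the scatter), only a modest step. Adding one methyl is a smaller edit, so the expected change is a number 4 percentage points lower from compound 3 to compound 4 (within the scatter), with no step beyond the scatter anticipated. For compound 4 the estimated value is 35%, with an expected range of 22% to 48%.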

Compound 4, percent of the compound remaining: 74%
Compound 4: middle estimate off by 39 percentage points, on the low side; the measured number lies above the stated range.
By their numbers in this assay, from the lowest: compound 2; then compounds 3 and 1 (each within the scatter of the next); then compound 4.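

In this assay, adding one methyl on a saturated chain carbon bound to an aromatic carbon gives a number 35 percentage points higher from compound 3 to compound 4 (beyond the scatter), so a very small edit at this place can produce a large change. The 2-ethylphenyl group also stands clear of the other two groups, with a number 53 percentage points higher from compound 2 to compound 4 (beyond the scatter) and a number 28 percentage points higher from compound 1 to compound 4 (beyond the scatter). Nothing available here accounts for the jump. Going by these compounds, whether a longer chain, such as propyl, or a branched one, such as isopropyl, would hold or extend this rise stays open.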